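The compounds below may be only part of what the source reports. "The series", "measured", "known", "first", "only" and "open" are said of these compounds alone.

Three compounds built on one shared core, differing only in a substituted phenyl group, have been tested in a functional assay on SGC-7901 cells (Homo sapiens) for antiproliferative activity, read by MTT assay, with a stated time of 72 h; a higher number here means a weaker inhibitor, a lower number a stronger inhibitor. Compound 1 `COc1cc(-n2cnc3ccc(-c4cccc(O)c4)cc32)cc(OC)c1OC`, which carries a hydroxyl on that phenyl group, gives 53 nM. Compound 2 `COc1cc(-n2cnc3ccc(-c4ccc(C)cc4)cc32)cc(OC)c1OC`, which carries a methyl, gives 200 nM. Compound 3 `COc1cc(-n2cnc3ccc(-c4ccc(Cl)cc4)cc32)cc(OC)c1OC`, the 4-chlorophenyl member, gives 1270 nM, the highest number of the three, which makes it the weakest inhibitor of this small set.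

Compound 4 `COc1ccc(-c2ccc3ncn(-c4cc(OC)c(OC)c(OC)c4)c3c2)cc1` has not yet been measured. It keeps the core of compound 3 but has methoxy in place of chloro on an aromatic carbon, turning 4-chlorophenyl into 4-methoxyphenyl (methoxy in place of chloro on an aromatic carbon).

The closest guide is the step of a 6.4-fold higher number from compound 2 to compound 3 (0.80 log units; beyond the scatter), a modest change in which chloro replaces methyl at the same place. Read backwards, it shows one case where losing the chloro lowered the number. The steps of a 3.8-fold higher number from compound 1 to compound 2 (0.58 log units; beyond the scatter) and a 24-fold higher number from compound 1 to compound 3 (1.38 log units; beyond the scatter) show how far this series can move, but they also change the group's position. For the measured compounds named here, no methoxy compound has been measured, so this expectation rests on thin evidence.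

The step expected in this assay is modest and downward, an estimated 4.5-fold lower number from compound 3 to compound 4 (0.66 log units; beyond the scatter). Compound 4 is expected to give about 280 nM, with an estimated range from 90 nM to 900 nM.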

Compound 4, half-maximal inhibitory concentration: 82 nM
Compound 4: the middle estimate sits 3.4-fold (0.53 log units) above what was measured; measured number outside the range, below it.
By their numbers in this assay, from the lowest: compounds 1 and 4 (each within the scatter of the next); then compound 2; then compound 3.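

In this assay, the place para to a large group turns out to be far more sensitive than the methyl and chloro pair alone could show: methoxy in place of chloro gives a 15-fold lower number from compound 3 to compound 4 (1.19 log units; beyond the scatter), a large move for a small exchange. Methoxy also differs from methyl at this same place, with a 2.4-fold lower number from compound 2 to compound 4 (0.39 log units; beyond the scatter), so among these three groups the number falls from chloro to methyl to methoxy, an order that holds for these three alone. The hydroxyl is no longer the only route to a low number in this small set, since the step from the 3-hydroxyphenyl group to the 4-methoxyphenyl group is a 1.5-fold higher number from compound 1 to compound 4 (0.19 log units; within the scatter), and that step changes both the group and its position, so neither change can be read alone.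

Still open, going by these compounds, is whether a larger ether such as ethoxy, or an amine, would hold the number as low at this place, and whether hydroxyl and methoxy would stay this close if each sat where the other sits. Nothing available explains why these groups differ so widely.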